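From Chloro to Trifluoromethyl: an Analogue Expected to Stay Inactive

The compounds below may be only part of what the source reports. "The series", "measured", "known", "first", "only" and "open" are said of these compounds alone.

Compound 1 `O=C(Nc1cccc(-c2cccc(Cl)c2)c1)C(Cl)Cl` was tested in a functional assay on KB 3-1 cells (Homo sapiens) for cytotoxicity, read by MTT assay, with a stated time of 68 h; on this read-out higher numbers stand for weaker inhibition and lower numbers for stronger inhibition. In this assay compound 1 gives only a limit, > 50000 nM. Compound 2 `O=C(Nc1cccc(-c2ccc(C(F)(F)F)cc2)c1)C(Cl)Cl` likewise shows only a limit in this assay, > 50000 nM. Compound 1 thus sits at the limit of > 50000 nM in this assay, at which 2 of the 2 values shown sit, so no order among the measured compounds can be read. Compound 3 `O=C(Nc1cccc(-c2cccc(C(F)(F)F)c2)c1)C(Cl)Cl` differs from compound 1 by trifluoromethyl in place of chloro on an aromatic carbon. Within the data shown here, no step between measured compounds is available, and the expected step that the limit leaves unreadable from compound 1 to compound 3 is none beyond the scatter. Compound 3 is expected to give 80000 nM, in a range from 30000 nM to 300000 nM, most likely reported again only as a limit.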

Compound 3, half-maximal inhibitory concentration: > 50000 nM
Compound 3 gave a limit, no number; the forecaster's own chance of this, stated with the estimate: 85%; the middle value lies beyond the limit too.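

No step can be read from compound 1 to compound 3, as both give only a limit: the limit of > 50000 nM in this assay, at which 3 of the 3 values shown sit.

The compounds shown leave open whether trifluoromethyl in place of chloro alters activity at all, and what change to the shared core would yield a measured number.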